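The source may hold more compounds than are shown below. What is called first, only, known or untested is meant among the compounds shown, and "the series" means these compounds.

The series rests on two cores. Compound 1 `O[C@@H]1Cc2cc(Cl)ccc2N[C@H](c2cccs2)C1` and compound 2 `Cc1ccsc1[C@@H]1C[C@H](O)Cc2cc(Cl)ccc2N1` share one core; compound 3 `O[C@@H]1Cc2cc(OC(F)(F)F)ccc2N[C@H](c2ccco2)C1` and the as yet unmeasured compound 4 `Cc1ccc([C@@H]2C[C@H](O)Cc3cc(OC(F)(F)F)ccc3N2)o1` share the other. The difference between the two cores is not broken down here. In an ADME assay on THP-1 cells (Homo sapiens) for cytotoxicity (a higher number here means that more compound is tolerated, a lower number that less compound is tolerated), compound 1 gives 115000 nM. In this assay compound 2 gives 181000 nM. Compound 3 gives 135000 nM in this assay; all three numbers lie within the scatter of one another, so no order among them can be read.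

One change recurs. From compound 1 to compound 2 it is methyl in place of hydrogen on an aromatic carbon, and the step it made is a 1.6-fold higher number from compound 1 to compound 2 (0.20 log units; within the scatter). From compound 3 to compound 4 it is methyl in place of hydrogen on an aromatic carbon. The two are the same kind of change, not the same: in compound 2 the methyl sits on a five-membered aromatic ring with 1 sulfur, next to the ring atom that bears a large group and two ring bonds from the ring sulfur, whereas in compound 4 it sits on a five-membered aromatic ring with 1 oxygen, next to the ring oxygen and two ring bonds from the ring atom that bears a large group. Among the measured compounds shown here, only one measured pair carries this change, and it lies on the other core.

For the measured compounds named here, for compound 4 the expected step is a 1.2-fold higher number from compound 3 to compound 4 (0.07 log units; within the scatter), resting on the single earlier step of a 1.6-fold higher number from compound 1 to compound 2 (0.20 log units; within the scatter), which stayed within the scatter, so a number near that of compound 3 is expected. Compound 4 is estimated at 160000 nM, with an expected range from 90000 nM to 280000 nM.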

Compound 4, half-maximal cytotoxic concentration: 124000 nM
Compound 4: the middle estimate sits 1.3-fold (0.11 log units) above what was measured, and the stated range covers the measured number.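

In this assay, methyl in place of hydrogen on an aromatic carbon gives a 1.1-fold lower number from compound 3 to compound 4 (0.04 log units; within the scatter) and, set beside the earlier step, the two do not differ beyond the scatter: the same change on two cores in this assay, a 1.6-fold higher number (0.20 log units; within the scatter) from compound 1 to compound 2 and a 1.1-fold lower number (0.04 log units; within the scatter) from compound 3 to compound 4, 1.7-fold (0.23 log units) apart, within the scatter of two such steps. Across these two pairs, the change therefore carries from the core of compound 1 to the core of compound 3 without a difference that can be read, and neither step on its own can be told from the scatter. Among the compounds shown here, this does not show that methyl is without effect or that the two cores respond alike in general, since there are only two pairs, the methyl sits at a different place in each, and a small real difference between them could lie hidden in the scatter.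

Still open, on these data alone, is whether any group on the five-membered aromatic ring moves the number beyond the scatter, for example a longer chain such as ethyl, an amine or a carboxylic acid in place of the methyl. For the compounds shown here, also open is how the difference between the two cores bears on the number, as no pair here separates the chlorine from the trifluoromethoxy group or the ring with sulfur from the ring with oxygen.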